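The source may report more compounds than this note shows. Statements on the series, on what has been measured and on what is new or still open speak of the compounds shown alone.

Three compounds share a common core and differ only in the aryl group on the amine. The series opens with compound 1 `NCc1csc(Nc2cccc3ccccc23)n1`. In an assay on CCRF-CEM cells for displacement of a labelled ligand from C-C chemokine receptor type 4 (Homo sapiens) (on this read-out higher numbers stand for weaker inhibition and lower numbers for stronger inhibition), compound 1 gives only a limit, > 25000 nM. Compound 2 `CC(C)(C)c1csc(Nc2cccc3c2CCCC3)n1` gives 210 nM in this assay. Compound 3 `CC(C)(C)c1csc(Nc2cccc3[nH]ccc23)n1` gives 490 nM in this assay; of the two numbers recorded, compound 3 stands at the higher one, with compound 2 as its nearest neighbour at a lower number, and the gap between them lies beyond the usual scatter. One of the three values sits at the limit (the limit of > 25000 nM in this assay, at which 1 of the 3 values shown sits).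

Compound 4 `CCn1ccc2c(Nc3nc(C(C)(C)C)cs3)cccc21` differs from compound 3 in a single place: ethyl in place of hydrogen on an aromatic nitrogen. Among the measured compounds shown here, no step of this kind has been measured among the compounds above, so the size of the step in this assay can only be estimated. The change is small, and the expectation is for a step near the edge of the scatter, with a modest weakening thought somewhat more likely than a strengthening. Compound 4 is therefore expected to give about 700 nM in this assay, between 200 nM and 2500 nM. The step this implies is estimated at a 1.4-fold higher number from compound 3 to compound 4 (0.15 log units; within the scatter).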

Compound 4, half-maximal inhibitory concentration: 210 nM
For compound 4 the middle estimate is 3.3-fold (0.52 log units) above the measured one, within the range that was stated.
By their numbers in this assay, from the lowest: compounds 2 and 4 (each within the scatter of the next); then compound 3. At a limit, above all of these: compound 1.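

Ethyl in place of hydrogen on an aromatic nitrogen gives a 2.3-fold lower number from compound 3 to compound 4 (0.37 log units; beyond the scatter) in this assay and is the first change at a single place that can be read in this set. It shows that the hydrogen on this nitrogen can be replaced without losing inhibition, and that this position accepts a group of two carbons with a modest gain in this read-out. Nothing in the data shown accounts for the size or direction of this step.

On these data alone, whether the gain continues with a longer chain such as propyl or butyl, or holds for a smaller methyl group, remains open. As far as these compounds go, it is also open how a chain ending in an amine or a carboxylic acid would behave on this nitrogen.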